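The compounds below may be only part of what the source reports. "The series", "measured", "known", "first", "only" and "open" are said of these compounds alone.

Measured so far in a functional assay on the whole organism (artery, strain albino) with Rattus norvegicus as the target, with a stated time of 360 min, at a dose of 10 mg/kg by the oral route; a higher number here means more inhibition at the dose given (going by the name of the read-out), a lower number less inhibition:
Compound 1 `COc1ccc(C2N=C(SCc3ccccc3)NC(C)=C2C(=O)Nc2ccc(F)cc2)cc1OC` gives 3.6%.
Compound 2 `COc1ccc(C2N=C(SCc3cccc(Cl)c3)NC(C)=C2C(=O)Nc2ccc(F)cc2)cc1OC` gives 20.1%.
Compound 3 `CC1=C(C(=O)Nc2ccc([N+](=O)[O-])cc2)C(c2cccc([N+](=O)[O-])c2)N=C(SCc2ccccc2)N1` gives 32.5%.

Compound 4 `CC1=C(C(=O)Nc2ccc([N+](=O)[O-])cc2)C(c2cccc([N+](=O)[O-])c2)N=C(SCc2ccccc2Cl)N1` has not yet been measured. It arises from compound 3 by one change, (chloro in place of hydrogen on an aromatic carbon). A change of the same kind has been made once before, from compound 1 to compound 2, (chloro in place of hydrogen on an aromatic carbon), and there it gave a number 16.5 percentage points higher from compound 1 to compound 2 (beyond the scatter). The two are not the same change: in compound 2 the chloro sits meta to a large group, in compound 4 ortho to a large group. The difference between the core of compound 1 and the core of compound 3 is not broken down here; compound 3 simply stands highest of the three measured numbers. For compound 4 a rise of similar size is expected, a number 9.5 percentage points higher from compound 3 to compound 4 (within the scatter), because the earlier step gave a number 16.5 percentage points higher from compound 1 to compound 2 (beyond the scatter), with wide room for the different place and core. Compound 4 is therefore estimated at 42%, between 24% and 62%.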

Compound 4, a percentage reported as inhibition, in the whole organism at one dose (the size of the read-out at that dose, not a potency): 17.5%
Beside the measured number, compound 4's estimate is 24.5 percentage points above it, and the stated range ends above it.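

In this assay the step to a 2-chlorobenzyl group gives a number 15 percentage points lower from compound 3 to compound 4 (beyond the scatter). A rise from adding a chloro on one core therefore cannot be assumed on another, as the two steps show: the same change on two cores in this assay, a number 16.5 percentage points higher (beyond the scatter) from compound 1 to compound 2 and a number 15 percentage points lower (beyond the scatter) from compound 3 to compound 4, 31.5 percentage points apart, beyond the scatter of two such steps What this does not show is the reason, since the two steps differ both in the core and in where the chloro sits, and two steps cannot separate these.

On these data alone, it remains open whether a 2-chlorobenzyl group would also lower the number on the core of compound 1, or whether the chloro placed as in compound 2 would raise it on the core of compound 3. Also open, as far as these compounds go, is how an amine or a carboxylic acid in place of the chloro would behave on either core.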